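This account rests on a few compounds, and the source may have more. Where it says the series, first, only, none or still open, it means among the compounds named here.

Compound 1 `Cc1cccc(Cn2c(CN3CCN(C(=O)c4ccc(C(F)(F)F)cc4)CC3)nc3ccccc32)c1` was examined in an assay on isolated protein for inhibition of aldehyde dehydrogenase 1A1 (Homo sapiens), read by spectrophotometry, tested at 10 uM (on this read-out higher numbers stand for more inhibition at the one concentration tested (going by the name of the read-out) and lower numbers for less inhibition), where compound 1 gives 22.9%. That is the lowest of the two numbers recorded, and the nearest neighbour, compound 2 `Cc1cccc(Cn2c(OC3CCN(C(=O)C4CC4)CC3)nc3ccccc32)c1`, gives 80.6% in this assay, a gap that lies beyond the scatter. Compound 2 differs from compound 1 in more than one place, so its values show only where each compound stands, not what any single change does. Compound 3 `Cc1cccc(Cn2c(CN3CCN(C(=O)c4cccs4)CC3)nc3ccccc32)c1` has not yet been measured in this assay. It differs from compound 1 in one place: thiophen-2-yl in place of 4-(trifluoromethyl)phenyl on a carbonyl carbon. Among the compounds with values here, no measured pair shows this change, so the size of its effect is unknown. The step from compound 1 to compound 3 is expected to be small and upward, a number 12.1 percentage points higher from compound 1 to compound 3 (beyond the scatter), at about the edge of the scatter. Compound 3 is estimated to give 35% in this assay, within a range from 10% to 65%.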

Compound 3, a percentage reported as inhibition, at one concentration (the size of the read-out at that concentration, not a potency): 60.8%
Compound 3: the middle estimate sits 25.8 percentage points below what was measured, and the stated range covers the measured number.
By their numbers in this assay, from the lowest: compound 1; then compound 3; then compound 2.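

In this assay, the group on the carbonyl carbon whose other neighbour is the amide-type nitrogen in a ring proves to matter: thiophen-2-yl in place of 4-(trifluoromethyl)phenyl gives a number 37.9 percentage points higher from compound 1 to compound 3 (beyond the scatter). Within the data shown here, this is the first comparison in which only one place differs, so it ties a change in inhibition to this position, which the gap between the two earlier compounds could not do. Nothing available explains the size of this step.

The compounds shown do not separate the part played by the sulfur-containing five-membered ring from that of losing the trifluoromethyl group, a question that a plain phenyl or a furan-2-yl on the same carbonyl carbon would address. From the compounds shown here alone, whether the same exchange has a similar effect on the core of compound 2 also remains open.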